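The compounds below may be only part of what the source reports. "The series", "measured", "known", "first", "only" and "open" are said of these compounds alone.

Working notes on a small antiproliferative series. Of the compounds shown here, two carry numbers so far. Compound 1 `CCNCC(=O)Nc1cc(OC)ccc1C(=O)c1cc(OC)c(OC)c(OC)c1` bears a (((ethylamino)methyl)carbonyl)amino group on its own core; in a functional assay on A2780 cells (Homo sapiens) for antiproliferative activity, read by MTT assay, with a stated time of 48 h (a higher number here means a weaker inhibitor, a lower number a stronger inhibitor), compound 1 gives 950 nM. Compound 2 `C=C(c1ccc(OC)cc1NC(=O)CO)c1ccc(OC)c2c1C=CC(C)(C)O2` has a different core and a ((hydroxymethyl)carbonyl)amino group; in this assay compound 2 gives 280 nM. Of the two numbers, compound 2 holds the lower one, and its gap to compound 1 lies beyond the usual scatter of repeated measurements.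

Compound 3 `C=C(c1ccc(OC)cc1NC(=O)CNCC)c1ccc(OC)c2c1C=CC(C)(C)O2` is not yet measured. It differs from compound 2 in one place (ethylamino in place of hydroxy on a saturated chain carbon bound to a carbonyl carbon). Within the data shown here, the change gives compound 3 the same side chain that compound 1 carries, but compound 1 sits on another core, so the pair of compound 1 and compound 2 does not isolate this change, and no step between measured compounds describes it. The expected step is therefore small, within the scatter, with no clear direction: a 1.1-fold higher number from compound 2 to compound 3 (0.03 log units; within the scatter). For compound 3 the estimated value in this assay is 300 nM, with a range from 120 nM to 750 nM, the width reflecting the absence of any matched pair for this change.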

Compound 3, half-maximal inhibitory concentration: 2010 nM
Compound 3: the middle estimate sits 6.7-fold (0.83 log units) below what was measured; the whole stated range lies below it.
By their numbers in this assay, from the lowest: compound 2; then compound 1; then compound 3.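

Among these compounds, on the shared core, the saturated chain carbon bound to a carbonyl carbon proves sensitive to the group it carries: in this assay, ethylamino in place of hydroxy gives a 7.2-fold higher number from compound 2 to compound 3 (0.86 log units; beyond the scatter), the only matched step and one that lies beyond the scatter. Both groups count the same hydrogen-bond donors and acceptors and neither carries a net charge, so those counts do not separate them, whereas ethylamino brings more heavy atoms, and this single step cannot say which difference in the groups matters. Nothing at hand bears on why the number rises with this change.

Still open, as far as these compounds go, is whether the rise follows the nitrogen of the ethylamino group or the length of its chain, a question that a plain amino group, a methylamino group or a methoxy group at this place would help to separate. Also open, from the compounds shown here alone, is whether the same change acts alike on the core of compound 1, which would take a hydroxy counterpart of compound 1 to read.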